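The source may hold more compounds than are shown below. What is called first, only, known or untested is meant among the compounds shown, and "the series" means these compounds.

Working notes on the series. Among the measured compounds shown here, in a functional assay on Raji cells (Homo sapiens) for antiproliferative activity, read by CCK-8 assay, with a stated time of 48 h (on this read-out higher numbers stand for weaker inhibition and lower numbers for stronger inhibition), compound 1 `C=CC(=O)Nc1cccc(-n2cnc3cnc(Nc4ccc(OC)cc4)nc32)c1` gives 31200 nM, the only actual number so far. Compound 2 `C=CC(=O)Nc1cccc(-n2cnc3cnc(Nc4ccc(N5CCN(CC)CC5)cc4OC)nc32)c1` reads > 40000 nM, which is a limit and not a number. The next compound to be read is compound 3 `C=CC(=O)Nc1cccc(-n2cnc3cnc(Nc4ccc(N5CCN(S(C)(=O)=O)CC5)cc4)nc32)c1`, which keeps the core of compound 1 and carries 4-(methylsulfonyl)piperazin-1-yl in place of methoxy on an aromatic carbon, para to a large group (4-(methylsulfonyl)piperazin-1-yl in place of methoxy on an aromatic carbon). For the measured compounds named here, no measured step covers this change, so the expectation rests on compound 1 at 31200 nM alone. A modest move toward stronger inhibition in this assay is expected, close to the scatter, and a reading that returns only a limit remains possible. The expected step is a 2.0-fold lower number from compound 1 to compound 3 (0.29 log units; within the scatter). For compound 3 the estimated value is 16000 nM, with an expected range of 4000 nM to 40000 nM.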

Compound 3, half-maximal inhibitory concentration: > 40000 nM
Compound 3 ended at the assay's limit; the forecaster's own chance of this, stated with the estimate: 30%; at least 2.5-fold (0.39 log units) between middle value and limit.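

Among the compounds shown here, at the aromatic carbon para to a large group, 4-(methylsulfonyl)piperazin-1-yl in place of methoxy gives the first step at this position: in this assay, the step is an at least 1.2-fold higher number from compound 1 to compound 3 (0.10 log units; that floor lies within the scatter). Compound 3 reads > 40000 nM, which is a limit and not a number. Going by these compounds, the change therefore shows no move toward stronger inhibition, and the full size of the step stays unknown because the read-out ends at the limit: the limit of > 40000 nM in this assay, at which 2 of the 3 values shown sit.

Steps involving compound 2 cannot be read. Open, on these data alone, is whether a simple amine or a morpholin-4-yl group at this position would give a measurable number, and whether any group here gives a reading clearly below that of compound 1.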